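Benzyl ether isoxazole esters: cytotoxicity limits and a difluoro analogue

This account rests on a few compounds, and the source may have more. Where it says the series, first, only, none or still open, it means among the compounds named here.

Compound 1 `CCOC(=O)c1cc(-c2cccc(OCc3ccccc3)c2)on1`: in an ADME assay on Vero cells (Chlorocebus sabaeus) for cytotoxicity, with a stated time of 72 h (on this read-out lower numbers stand for stronger inhibition and higher numbers for weaker inhibition), compound 1 gives > 128000 nM, a limit of the assay.
Compound 2 `CCOC(=O)c1cc(-c2cccc(OCc3cccc(C#N)c3)c2)on1`: in this assay compound 2 gives > 128000 nM, a limit of the assay.
Compound 3 `CCOC(=O)c1cc(-c2cccc(OCc3ccccc3Cl)c2)on1`: in this assay compound 3 gives > 128000 nM, a limit of the assay.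

Compound 3 stands where every measured compound stands: at a limit, with no number to rank it against the other two. The step from compound 1 to compound 2 (a step that the two limits leave unreadable from compound 1 to compound 2) is a cyano in place of a hydrogen on an aromatic carbon, and the step from compound 1 to compound 3 (a step that the two limits leave unreadable from compound 1 to compound 3) a chloro in the same kind of position; neither size can be read, because of the limit of > 128000 nM in this assay, at which 3 of the 3 values shown sit. The step from compound 2 to compound 3 (a step that the two limits leave unreadable from compound 2 to compound 3) is likewise unreadable.

Compound 4 `CCOC(=O)c1cc(-c2cccc(OCc3cccc(F)c3F)c2)on1` differs from compound 3 by 2,3-difluorophenyl in place of 2-chlorophenyl on a saturated chain carbon bound to an oxygen on an aromatic ring. All three measured steps bear on it only in that none reached a readable value. The step from compound 3 to compound 4 in this assay is therefore expected to be a step that the limit leaves unreadable from compound 3 to compound 4, that is, none beyond the scatter. Compound 4 is estimated at 200000 nM, in the range 100000 nM to 500000 nM, most likely reported again only as a limit.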

Compound 4, half-maximal inhibitory concentration: > 128000 nM
Compound 4: a limit, no number (the forecaster's own chance of this, stated with the estimate: 90%); the middle value is on the limit's open side.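

Compound 4 sits at a limit in this assay, as do compound 1, compound 2 and compound 3, so no step among them can be read: the limit of > 128000 nM in this assay, at which 4 of the 4 values shown sit.

The compounds shown leave open whether any of the four differs from another in this assay, and at what concentration any of them reaches half-maximal inhibition.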